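Swapping the aryl group on a shared dicyanopyrimidine-type core

A few compounds are considered here, and "the series" means these few. Any claim that something is new, unique, unknown or untested is made for them only; others in the source may bear on it.

Measured compounds:
compound 1 `CC(C)c1ccc(Nc2nc(SCc3cn(CC(=O)NC(=O)Nc4ccccn4)nn3)nc(-c3ccc(C(C)C)cc3)c2C#N)cc1` — 4380 nM
compound 2 `COc1cc(-c2nc(SCc3cn(CC(=O)NC(=O)Nc4ccccn4)nn3)nc(Nc3ccc(C(C)C)cc3)c2C#N)cc(OC)c1OC` — 1210 nM

Of the compounds shown here, two have been tested in a functional assay on B16-F10 cells (Mus musculus) for inhibition, read by MTT assay, with a stated time of 72 h; on this read-out lower numbers stand for stronger inhibition and higher numbers for weaker inhibition. Compound 1 gives 4380 nM, while compound 2 gives 1210 nM. Of the two numbers compound 2 has the lower one, and the step of a 3.6-fold lower number from compound 1 to compound 2 (0.56 log units; beyond the scatter) lies beyond the scatter, so compound 2 stands as the stronger inhibitor of the pair.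

Compound 3 `Cc1ccc(-c2nc(SCc3cn(CC(=O)NC(=O)Nc4ccccn4)nn3)nc(Nc3ccc(C(C)C)cc3)c2C#N)cc1` has not yet been measured. It differs from compound 2 in one place: 4-methylphenyl in place of 3,4,5-trimethoxyphenyl on an aromatic carbon. The group enters on an aromatic carbon of a six-membered aromatic ring with 2 nitrogen, the same position where the step from compound 1 to compound 2 was made.

Within the data shown here, that one step, a 3.6-fold lower number from compound 1 to compound 2 (0.56 log units; beyond the scatter), is the only measured change at this position, and it shows that the group here matters. Compound 3 carries an aryl group with a single small substituent and no hydrogen-bond acceptors, so it is expected to move back toward compound 1, giving a higher number in this assay, with the step of a 2.5-fold higher number from compound 2 to compound 3 (0.39 log units; beyond the scatter) estimated. Compound 3 is thus expected to give about 3000 nM, within a range of 1200 nM to 8000 nM.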

Compound 3, half-maximal inhibitory concentration: 35 nM
For compound 3 the middle estimate is 86-fold (1.93 log units) above the measured one; measured number outside the range, below it.
By their numbers in this assay, from the lowest: compound 3; then compound 2; then compound 1.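

The position is far more sensitive than the first pair suggested: in this assay, replacing 3,4,5-trimethoxyphenyl with 4-methylphenyl gives a 35-fold lower number from compound 2 to compound 3 (1.54 log units; beyond the scatter), and the earlier step at this position was much smaller. Exchanging isopropyl for methyl on the aryl ring gives a 130-fold lower number from compound 1 to compound 3 (2.10 log units; beyond the scatter), so a change confined to one small substituent can have a very large effect on this read-out, and the two carbon-only aryl groups, 4-isopropylphenyl and 4-methylphenyl, mark the two ends of the span, with compound 2 falling inside it. Among these compounds, nothing available here explains why so small a change moves the number so far.

On these data alone, what remains open is how narrowly this result depends on the methyl group: 4-ethylphenyl, 4-chlorophenyl, 4-methoxyphenyl or plain phenyl would show whether the low number belongs to methyl alone or extends to other small groups. These three compounds also leave open whether the same order would hold on other cell types, since all of the numbers here come from one kind of cell.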